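This account rests on a few compounds, and the source may have more. Where it says the series, first, only, none or still open, it means among the compounds named here.

In a functional assay on U-266 cells (Homo sapiens) for antiproliferative activity, read by MTT assay, with a stated time of 72 h (on this read-out higher numbers stand for weaker inhibition and lower numbers for stronger inhibition), compound 1 (`C[C@H](NC(=O)/C(C#N)=C/c1cccc(Br)n1)c1ccc(Br)cc1`) gives 1800 nM. Compound 2 (`N#C/C(=C\c1cccc(Br)n1)C(=O)N[C@@H]1CCCc2ccccc21`) gives 1900 nM, and compound 3 (`N#C/C(=C\c1cccc(Br)n1)C(=O)N[C@@H](CO)c1ccccc1`) gives 3500 nM. Compound 1 lies within the usual scatter of both, so it stands level with them. Compound 4 (`COc1cccc([C@H](C)NC(=O)/C(C#N)=C/c2cccc(Br)n2)c1`) keeps the core of compound 1 but carries 3-methoxyphenyl in place of 4-bromophenyl on a saturated chain carbon bound to an amide-type nitrogen and a saturated chain carbon. Among the measured compounds shown here, no measured pair shows this exact change. Compound 2, which lacks the 4-bromophenyl group, still gives 1900 nM, so no step beyond the scatter is expected in this assay. The estimated step of a 1.4-fold higher number from compound 1 to compound 4 (0.14 log units; within the scatter) is small, towards a slightly higher number. For compound 4 the estimate is 2500 nM, with an expected range of 1000 nM to 6000 nM.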

Compound 4, half-maximal inhibitory concentration: 2800 nM
Compound 4: middle estimate off by 1.1-fold (0.05 log units), on the low side; the range from low to high includes it.
By their numbers in this assay, from the lowest: compounds 1, 2, 4 and 3 (each within the scatter of the next).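

In this assay, among the compounds shown here, this pair gives the first direct reading at this position: a 1.6-fold higher number from compound 1 to compound 4 (0.19 log units; within the scatter) stays within the scatter. Replacing 4-bromophenyl with 3-methoxyphenyl on this saturated chain carbon therefore gives no readable change, even though both the group and its place on the aromatic ring differ. No supporting measurement is available to explain this result. Going by these compounds, whether an aromatic ring carrying an amine or a carboxylic acid would give a step beyond the scatter remains open. So does the outcome with 4-methoxyphenyl, which would keep the methoxy group but change its place.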